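A few compounds are considered here, and "the series" means these few. Any claim that something is new, unique, unknown or untested is made for them only; others in the source may bear on it.

Measured in a functional assay (strain AB) with Danio rerio as the target, read by microscopy, with a stated time of 1 h; a lower number here means that less compound is needed, a higher number that more compound is needed for the effect:
- Compound 1 `CN1CCc2c(sc(NC(=O)Nc3ccc(Cl)cc3)c2C(N)=O)C1`: 4700 nM
- Compound 2 `CC(C)(C)OC(=O)CCN1CCc2c(sc(NC(=O)Nc3ccc(Cl)cc3)c2C(N)=O)C1`: 1100 nM
- Compound 3 `CC(C)(C)OC(=O)CCCN1CCc2c(sc(NC(=O)Nc3ccc(Cl)cc3)c2C(N)=O)C1`: 560 nM

Compound 3 stands clearly apart from compound 1, with an 8.4-fold lower number from compound 1 to compound 3 (0.92 log units; beyond the scatter). Its value is not separated from that of compound 2, since a 2.0-fold lower number from compound 2 to compound 3 (0.29 log units; within the scatter).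

Compound 4 `CC(C)(C)OC(=O)CCCCN1CCc2c(sc(NC(=O)Nc3ccc(Cl)cc3)c2C(N)=O)C1` has not yet been measured. It carries (tert-butoxycarbonyl)methyl in place of tert-butoxycarbonyl on a saturated chain carbon, three bonds along the chain from an amine nitrogen in a ring.

For the measured compounds named here, the closest precedent is the same kind of change made one bond nearer the amine nitrogen, where a 2.0-fold lower number from compound 2 to compound 3 (0.29 log units; within the scatter). The larger 4.3-fold lower number from compound 1 to compound 2 (0.63 log units; beyond the scatter) replaces hydrogen with a whole ester-bearing chain, so it is a different change and bears on this one only weakly. In this assay, a small move towards a lower number is therefore expected, probably not beyond the scatter. The expected step is a 1.3-fold lower number from compound 3 to compound 4 (0.12 log units; within the scatter). For compound 4 the estimated value is 420 nM, with an expected range of 170 nM to 1100 nM.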

Compound 4, half-maximal effective concentration: 710 nM
Compound 4: middle estimate off by 1.7-fold (0.23 log units), on the low side, within the range that was stated.
By their numbers in this assay, from the lowest: compounds 3, 4 and 2 (each within the scatter of the next); then compound 1.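

In this assay, extending the chain to 4-(tert-butoxycarbonyl)butyl gives a 1.3-fold higher number from compound 3 to compound 4 (0.10 log units; within the scatter) and, measured from the shortest ester-bearing chain, a 1.5-fold lower number from compound 2 to compound 4 (0.19 log units; within the scatter), so compounds 2, 3 and 4 cannot be told apart by chain length. The longest chain still stands clear of the parent, with a 6.6-fold lower number from compound 1 to compound 4 (0.82 log units; beyond the scatter), which means that all three ester-bearing chains remain separated from compound 1. Nothing measured here accounts for this lack of separation among the chain lengths.

The compounds shown leave open whether a carboxylic acid or an amine in place of the tert-butyl ester would keep values like these. They also leave open whether a plain alkyl chain of the same length would do so, or whether a longer chain would separate from compound 3.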